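A few compounds are considered here, and "the series" means these few. Any claim that something is new, unique, unknown or untested is made for them only; others in the source may bear on it.

Working notes on the series. Compound 1 `O=Cc1cn(-c2ccccc2)nc1-c1ccc(Cl)cc1` gives 29500 nM in a functional assay on A549 cells (Homo sapiens) for antiproliferative activity, read by MTT assay, with a stated time of 48 h (on this read-out higher numbers stand for weaker inhibition and lower numbers for stronger inhibition), the highest of the three numbers in hand. Compound 3 `Fc1ccc(-c2nn(-c3ccccc3)cc2-c2nc3cc(Cl)c(Cl)cc3[nH]2)cc1` gives 15700 nM, a value within the scatter of compound 1, while compound 2 `Fc1ccc(-c2nn(-c3ccccc3)cc2-c2nc3cc(F)ccc3[nH]2)cc1` gives 1130 nM, a gap from compound 1 that lies beyond the scatter. Compound 4 `Clc1ccc(-c2nn(-c3ccccc3)cc2-c2nc3ccccc3[nH]2)cc1` has not been measured in this assay. Against compound 1 the change is 1H-benzimidazol-2-yl in place of formyl on an aromatic carbon. For the measured compounds named here, no measured pair isolates this change. As both benzimidazolyl compounds 2 and 3 sit below compound 1, compound 4 is expected to sit lower as well, with an estimated step of a 5.9-fold lower number from compound 1 to compound 4 (0.77 log units; beyond the scatter) beyond the scatter. The estimate for compound 4 in this assay is 5000 nM, within a range of 1000 nM to 25000 nM.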

Compound 4, half-maximal inhibitory concentration: 5960 nM
For compound 4 the middle estimate is 1.2-fold (0.08 log units) below the measured one; the range from low to high includes it.
By their numbers in this assay, from the lowest: compound 2; then compound 4; then compounds 3 and 1 (each within the scatter of the next).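

In this assay, this pair isolates the change directly and gives a 4.9-fold lower number from compound 1 to compound 4 (0.69 log units; beyond the scatter), so 1H-benzimidazol-2-yl in place of formyl on this aromatic carbon lowers the number with the rest of the core of compound 1 held the same. The step is modest and rests on this single pair. No measured evidence on hand bears on its cause. As far as these compounds go, whether an amide or a plain phenyl group on this carbon would give a similar step remains open. Compounds 2 and 3 differ from compound 4 in more than one place, so the effect of substituents on the benzimidazolyl group cannot be read.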